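The source may report more compounds than this note shows. Statements on the series, on what has been measured and on what is new or still open speak of the compounds shown alone.

Compound 1 (`Nc1nc2[nH]c(CCSCCC(=O)NCc3ccccn3)cc2c(=O)[nH]1`) gives (11900 nM)
Compound 2 (`Nc1nc2[nH]c(CCSCC(=O)N[C@@H](CCC(=O)O)C(=O)O)cc2c(=O)[nH]1`) gives (442 nM)

In a functional assay on SW-620 cells (Homo sapiens) for antiproliferative activity, read by MTT assay, with a stated time of 72 h, in the presence of a further agent that is not named here (on this read-out higher numbers stand for weaker inhibition and lower numbers for stronger inhibition), compound 2 holds the lower of the two numbers (442 nM), and compound 1 holds the higher (11900 nM). The gap between them lies outside the usual scatter. These two compounds differ in more than one place, so they isolate no single change. Compound 3 (`Nc1nc2[nH]c(CCSCC(=O)NCc3cccnc3)cc2c(=O)[nH]1`) departs from compound 2 on the amide-type nitrogen only ((pyridin-3-yl)methyl in place of 1,3-dicarboxypropyl on an amide-type nitrogen), with (pyridin-3-yl)methyl in place of 1,3-dicarboxypropyl. For the measured compounds named here, compound 1 also lacks the 1,3-dicarboxypropyl group and gives the higher number (11900 nM), which is the only guide available and a rough one. In this assay a large step towards weaker inhibition, beyond the scatter, is therefore expected (an 18-fold higher number from compound 2 to compound 3 (1.26 log units; beyond the scatter)). For compound 3 the estimated value is (8000 nM), with an expected range from 1500 nM to 40000 nM (both ends estimated).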

Compound 3, half-maximal inhibitory concentration: 25300 nM
For compound 3 the middle estimate is 3.2-fold (0.50 log units) below the measured one; measured number inside the range.
By their numbers in this assay, from the lowest: compound 2; then compound 1; then compound 3.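

In this assay, putting (pyridin-3-yl)methyl in place of 1,3-dicarboxypropyl on the amide-type nitrogen gives a 57-fold higher number from compound 2 to compound 3 (1.76 log units; beyond the scatter), a large step towards weaker inhibition. For the compounds shown here, compound 1 and compound 2 differ in more than one place, so this is the first comparison that ties a loss of this size to this position and this change alone, with the rest of the structure held constant. The data shown offer no explanation for the size of the step.

Going by these compounds alone, the single step leaves open whether the lower number of compound 2 depends on the whole 1,3-dicarboxypropyl group or only on part of it, such as a shorter chain ending in a carboxylic acid. It also leaves open how a phenylmethyl group on the same nitrogen would compare with (pyridin-3-yl)methyl.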